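Compound 4 as a pyridin-2-ylamino variant of compound 3

This account rests on a few compounds, and the source may have more. Where it says the series, first, only, none or still open, it means among the compounds named here.

Three measured compounds share one core and differ only on a saturated ring carbon. In an assay on CHO cells for displacement of a labelled ligand from 5-hydroxytryptamine receptor 1D (Homo sapiens) (on this read-out higher numbers stand for weaker inhibition and lower numbers for stronger inhibition), compound 1 `c1ccc2c(c1)CCC2NC1CCN(CCCc2c[nH]c3ccc(-n4cnnc4)cc23)CC1` gives 8.9 nM, compound 2 `CC(C)=CCCN(C)C1CCN(CCCc2c[nH]c3ccc(-n4cnnc4)cc23)CC1` gives 2.6 nM, and compound 3 `CN(Cc1ccco1)C1CCN(CCCc2c[nH]c3ccc(-n4cnnc4)cc23)CC1` gives 9.3 nM, the highest of the three numbers. The step of a 1.0-fold higher number from compound 1 to compound 3 (0.02 log units; within the scatter) lies within the scatter, while a 3.6-fold higher number from compound 2 to compound 3 (0.55 log units; beyond the scatter) is modest. Compound 4 `c1ccc(NCC2CCN(CCCc3c[nH]c4ccc(-n5cnnc5)cc34)CC2)nc1` has not yet been measured; the change is ((pyridin-2-yl)amino)methyl in place of ((furan-2-yl)methyl)(methyl)amino on a saturated ring carbon. For the measured compounds named here, no measured step exchanges the amine substituent for a ((pyridin-2-yl)amino)methyl group, so the expectation rests only on the narrow spread among compounds 1 to 3, and the step of a 1.1-fold higher number from compound 3 to compound 4 (0.03 log units; within the scatter) is expected to stay within the scatter. Compound 4 is therefore estimated at 10 nM, with a range from 3 nM to 35 nM.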

Compound 4, half-maximal inhibitory concentration: 1.7 nM
Compound 4: middle estimate off by 5.9-fold (0.77 log units), on the high side; measured number outside the range, below it.
By their numbers in this assay, from the lowest: compounds 4 and 2 (each within the scatter of the next); then compounds 1 and 3 (each within the scatter of the next).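

Placing ((pyridin-2-yl)amino)methyl on this saturated ring carbon gives a 5.5-fold lower number from compound 3 to compound 4 (0.74 log units; beyond the scatter) in this assay and a 5.2-fold lower number from compound 1 to compound 4 (0.72 log units; beyond the scatter) in the same assay, so the position can reach lower numbers than those two compounds showed. The a 1.5-fold lower number from compound 2 to compound 4 (0.18 log units; within the scatter) stays within the scatter, so the open-chain group of compound 2 and the aromatic group of compound 4 sit at the same level. The compounds shown leave open whether a phenyl ring or a pyridin-3-yl ring in place of the pyridin-2-yl ring would hold this level. No data shown here explain the difference.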